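The source may hold more compounds than are shown below. What is called first, only, known or untested is meant among the compounds shown, and "the series" means these compounds.

Measured so far in an ADME assay on PC-3 cells (Homo sapiens) for cytotoxicity, read by WST assay, tested at 100 uM; on this read-out higher numbers stand for more inhibition at the one concentration tested (going by the name of the read-out) and lower numbers for less inhibition:
- compound 1 `O=C(Nc1ccc(Cl)cn1)C1CCCN(C(=O)c2cc(C(F)(F)F)cc(C(F)(F)F)c2)C1` gives 0%
- compound 2 `Cc1cccc(C(=O)N2CCCC(C(=O)Nc3ccc(Cl)cc3)C2)c1` gives 0%
- compound 3 `CCc1cccc(NC(=O)C2CCCN(C(=O)c3cc(C(F)(F)F)cc(C(F)(F)F)c3)C2)c1` gives 0%

On these numbers compound 3 stands level with compound 1 and compound 2: none of the three shows any inhibition at the single concentration tested, and the gaps between them lie within the usual scatter. For the measured compounds named here, the one step that touches compound 3 directly is no change at the digits printed from compound 1 to compound 3 (within the scatter), which exchanged one group on an amide-type nitrogen without any visible effect. Compound 2, built on the same shared core with a different ring on the amide nitrogen, sits at the same level.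

Compound 4 `O=C(Nc1cccc(Oc2ccccc2)c1)C1CCCN(C(=O)c2cc(C(F)(F)F)cc(C(F)(F)F)c2)C1` differs from compound 3 in this way: phenoxy in place of ethyl on an aromatic carbon

Going by the values given here, no measured step bears on a change of this kind, so the only guide is that three compounds, carrying three different groups on the amide nitrogen, all sit at the floor of the read-out. On that basis the step of a number 2 percentage points higher from compound 3 to compound 4 (within the scatter) is expected to stay within the scatter, with no clear direction. Compound 4 is therefore estimated to give 2% in this assay, within a range from 0% to 20%.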

Compound 4, a percentage reported as inhibition, at one concentration (the size of the read-out at that concentration, not a potency): 1%
For compound 4 the middle estimate is 1 percentage points above the measured one; the measured number falls inside the stated range.
By their numbers in this assay, from the lowest: compounds 1, 2, 3 and 4 (each within the scatter of the next).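

In this assay, putting phenoxy in place of ethyl gives a number 1 percentage points higher from compound 3 to compound 4 (within the scatter). For the compounds shown here, this is the first look at a change on an aromatic carbon meta to a large group, rather than a swap of the whole group on the amide nitrogen, and the change is a large one: 7 heavy atoms enter where 2 leave, bringing a six-membered aromatic ring and 1 hydrogen-bond acceptor, yet the read-out shows no real difference. Nothing available explains this lack of effect.

Because compound 3 and compound 4 both sit close to the bottom of the read-out, this pair cannot show whether other groups at this position could produce clear inhibition of these cells. An amine or a carboxylic acid on this aromatic carbon, or a longer chain such as butyl, remains an open case, and so does the question of whether compound 4 would stay this quiet in a test that spans several concentrations.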